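Bromo-to-chloro swap on two related hydroxamate cores

A few compounds are considered here, and "the series" means these few. Any claim that something is new, unique, unknown or untested is made for them only; others in the source may bear on it.

Compound 1 `O=C(CCC1=CCN(CCCc2ccc(Br)cc2)C1=O)NO` and compound 2 `O=C(CCC1=CCN(CCCc2ccc(Cl)cc2)C1=O)NO` share one core; compound 3 `O=C(CCC1=CCN(Cc2cccc(Br)c2)C1=O)NO` and compound 4 `O=C(CCC1=CCN(Cc2cccc(Cl)c2)C1=O)NO` share another. How the two cores differ is not broken down here.

In a functional assay on ACHN cells (Homo sapiens) for inhibition, read by sulforhodamine B assay (a higher number here means a weaker inhibitor of growth, a lower number a stronger inhibitor of growth), compound 1 gives 3330 nM, and compound 2 gives 3330 nM. The change between them is chloro in place of bromo on an aromatic carbon, and the step it made is no change at the digits printed from compound 1 to compound 2 (within the scatter). In this assay compound 3 gives 3330 nM, level with compound 1 and compound 2 at the digits shown, within the scatter of both.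

Compound 4 differs from compound 3 by chloro in place of bromo on an aromatic carbon. Within the data shown here, this is the same kind of change as the one from compound 1 to compound 2, but not the same: in compound 1 the halogen sits para to a large group, whereas in compound 3 it sits meta to a large group.

The step from compound 3 to compound 4 is expected to be no change at the digits printed from compound 3 to compound 4 (within the scatter), because the earlier step of no change at the digits printed from compound 1 to compound 2 (within the scatter) stayed within the scatter, and nothing among the three measured compounds points to any effect of the halogen identity. Compound 4 is therefore estimated at 3330 nM, with a likely range from 1700 nM to 6700 nM.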

Compound 4, concentration for 50% growth inhibition: 3330 nM
Estimate against measurement, compound 4: no gap at the digits printed; low and high end bracket the measured number.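

In this assay, chloro in place of bromo on an aromatic carbon, here meta to a large group, gives no change at the digits printed from compound 3 to compound 4 (within the scatter), and the same change on the two cores agrees: the same change on two cores in this assay, no change at the digits printed (within the scatter) from compound 1 to compound 2 and no change at the digits printed (within the scatter) from compound 3 to compound 4, 1.0-fold (0.00 log units) apart, within the scatter of two such steps. Within these two cores, the swap therefore carries over as a null result, and the identity of this halogen does not separate the compounds in either pair. This does not show that the swap would stay silent on other cores, and it gives no test of whether a step of measurable size would carry from one core to another.

Going by these compounds, it remains open whether a different group on the same aromatic carbon, such as methoxy, nitrile or an amine, would shift growth inhibition away from the level seen with these halogens. Also open, on these data alone, is what a carboxylic acid in place of the hydroxamate, or a longer chain carrying the halogenated aromatic ring, would do in this assay.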